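The source may report more compounds than this note shows. Statements on the series, on what has been measured and on what is new or still open speak of the compounds shown alone.

Working notes on the series. Among the compounds with values here, in an in vitro ADME assay on microsomes from liver (Homo sapiens) for metabolic stability (on this read-out lower numbers stand for slow clearance and higher numbers for fast clearance), compound 1 `Cc1cccc(CNC(=O)[C@@H]2C[C@@H](c3nc(C)no3)CN(Cc3nc(-c4ccccc4)oc3C)C2)n1` gives 105 mL.min-1.g-1, the higher of the two numbers so far, while compound 2 `Cc1oc(-c2ccccc2)nc1CN1CCC[C@@H](C(=O)NCc2cccc(N)n2)C1` gives 49 mL.min-1.g-1, lower by a margin beyond the scatter. Compound 3 `Cc1cccc(CNC(=O)[C@H]2C[C@H](c3nc(C)no3)CN(Cc3nc(-c4ccccc4)oc3C)C2)n1` is the mirror image of compound 1, with the same atoms and bonds: the two compounds have the same atoms and bonds and differ only in configuration as drawn: 2 of 2 stereo elements differ (all stereocentres are inverted: mirror images); a stereocentre at a saturated ring carbon is drawn R in compound 1 and S in compound 3; a stereocentre at a saturated ring carbon is drawn R in compound 1 and S in compound 3. Within the data shown here, no measured pair shows what inverting these stereocentres does in this assay, so no direction can be argued with confidence. The expected step, a 1.2-fold lower number from compound 1 to compound 3 (0.07 log units; within the scatter), is not expected to lie beyond the scatter. The estimate for compound 3 is 90 mL.min-1.g-1, with an expected range of 45 mL.min-1.g-1 to 180 mL.min-1.g-1.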

Compound 3, intrinsic clearance in microsomes: 290 mL.min-1.g-1
Compound 3: the middle estimate sits 3.2-fold (0.51 log units) below what was measured; measured number outside the range, above it.
By their numbers in this assay, from the lowest: compound 2; then compound 1; then compound 3.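

In this assay, within the data shown here, inverting both stereocentres at saturated ring carbons gives a 2.8-fold higher number from compound 1 to compound 3 (0.44 log units; beyond the scatter), so this read-out distinguishes the two mirror images, which the earlier compounds could not show. The gap can be assigned to configuration alone because of one fact: the fact that compounds 1 and 3 differ only in the configuration as drawn. Which of the two stereocentres carries the step stays open, since both invert together here. Also open, going by these compounds, is whether the same inversion gives a step of this size in a compound carrying a carboxylic acid on the shared core.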